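Azole exchange on the saturated ring carbon of the core

The compounds below may be only part of what the source reports. "The series", "measured", "known", "first", "only" and "open" are said of these compounds alone.

Compound 1 `CC1(C)OC[C@@H](C/C=C\CCC(=O)O)[C@@H](c2ccnnc2)O1` gives the highest number among the measured compounds in an assay on isolated protein for inhibition of Thromboxane-A synthase (Homo sapiens) (on this read-out higher numbers stand for weaker inhibition and lower numbers for stronger inhibition), with 7400 nM. Compound 3 `CC1(C)OC[C@@H](C/C=C\CCC(=O)O)[C@@H](c2cncs2)O1` gives 80 nM, a step of a 93-fold lower number from compound 1 to compound 3 (1.97 log units; beyond the scatter). Compound 2 `CC1(C)OC[C@@H](C/C=C\CCC(=O)O)[C@@H](c2cnccn2)O1` shows only a limit of the assay, > 10000 nM. The corresponding step is an at least 1.3-fold higher number from compound 1 to compound 2 (0.13 log units; that floor lies within the scatter), resting on (the limit of > 10000 nM in this assay, at which 1 of the 3 values shown sits). Compound 4 `Cn1cncc1[C@H]1OC(C)(C)OC[C@H]1C/C=C\CCC(=O)O` differs from compound 1 by 1-methyl-1H-imidazol-5-yl in place of pyridazin-4-yl on a saturated ring carbon. The step to compound 3 bears most on this change, since it likewise puts a five-membered aromatic ring with 2 hetero atoms in place of pyridazin-4-yl, whereas the step to compound 2 keeps a six-membered ring and stays at the limit. A large decrease is therefore expected in this assay. Compound 4 is estimated at 100 nM, between 20 nM and 600 nM, an expected step of a 74-fold lower number from compound 1 to compound 4 (1.87 log units; beyond the scatter).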

Compound 4, half-maximal inhibitory concentration: 70 nM
The estimate for compound 4 lay 1.4-fold (0.15 log units) above the measured number; the range from low to high includes it.
By their numbers in this assay, from the lowest: compounds 4 and 3 (each within the scatter of the next); then compound 1. At a limit, above all of these: compound 2.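

In this assay, a second five-membered aromatic ring with 2 hetero atoms gives the same kind of large drop as the first (a 110-fold lower number from compound 1 to compound 4 (2.02 log units; beyond the scatter)), so the drop is not confined to 1,3-thiazol-5-yl. Replacing that ring with 1-methyl-1H-imidazol-5-yl leaves the number within the scatter (a 1.1-fold lower number from compound 3 to compound 4 (0.06 log units; within the scatter)), which shows that a sulfur-bearing ring is not required here. Against pyrazin-2-yl the step (an at least 140-fold lower number from compound 2 to compound 4 (2.15 log units; beyond the scatter)) is only a floor, since compound 2 stands at a limit: the limit of > 10000 nM in this assay, at which 1 of the 4 values shown sits.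

Still open, as far as these compounds go, is whether the methyl group on the imidazole ring matters. An ethyl group there, or a pyridin-3-yl ring on the same carbon, would test how far this result extends.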